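Compound 1 to Compound 4: Exchanging the Amide Substituent

The source may hold more compounds than are shown below. What is called first, only, known or untested is meant among the compounds shown, and "the series" means these compounds.

The measured compounds are:
compound 1 `Cc1cc(NC(=O)CN2CCC(c3cccc[n+]3[O-])CC2)ccc1F`, 18 nM;
compound 2 `O=C(CN1CCC(c2ccccn2)CC1)Nc1c(Cl)cc(Cl)cc1Cl`, 145 nM;
compound 3 `C=Cc1cccc(C(=O)NCN2CCC(c3cccc[n+]3[O-])CC2)c1`, 68 nM.

In a functional assay on HEK293 cells for agonist activity at D(4) dopamine receptor (Homo sapiens), read by FLIPR (a higher number here means that more compound is needed for the effect, a lower number that less compound is needed), compound 1 gives the lowest of the three numbers. Compound 3 is the nearest to it, with a number beyond the scatter higher, and compound 2 lies furthest away, also beyond the scatter. Compound 4 `O=C(CN1CCC(c2cccc[n+]2[O-])CC1)Nc1ccccc1F` has not yet been measured in this assay. It differs from compound 1 in one place: 2-fluorophenyl in place of 4-fluoro-3-methylphenyl on an amide-type nitrogen. In words, 2-fluorophenyl replaces 4-fluoro-3-methylphenyl on the amide-type nitrogen.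

For the measured compounds named here, no measured pair shows a step of this kind, so the direction of the change rests on the spread among the three measured compounds alone. The author expects the step from compound 1 to compound 4, a 3.3-fold higher number from compound 1 to compound 4 (0.52 log units; beyond the scatter), to run toward a higher number and to exceed the scatter. For compound 4 an estimate of 60 nM is given, with a range from 15 nM to 250 nM.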

Compound 4, half-maximal effective concentration: 270 nM
The estimate for compound 4 lay 4.5-fold (0.65 log units) below the measured number, outside the stated range (above it).
By their numbers in this assay, from the lowest: compound 1; then compound 3; then compounds 2 and 4 (each within the scatter of the next).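

In this assay, for the compounds shown here, the group on the amide-type nitrogen is the first place where a single change can be read, and 2-fluorophenyl in place of 4-fluoro-3-methylphenyl gives a 15-fold higher number from compound 1 to compound 4 (1.18 log units; beyond the scatter) as a large step beyond the scatter. Both groups are fluorinated phenyl rings with no hydrogen-bond donors or acceptors and no net charge, yet with the core of compound 1 kept, this exchange alone moves the number this far, so the position is far from indifferent to the choice of aryl group. Nothing available here bears on why the step is so large.

The compounds shown leave open how much of the step belongs to the lost methyl group and how much to the fluorine standing as 2-fluoro rather than 4-fluoro. Also open, on these data alone, is how a phenyl ring carrying a methoxy group or a nitrile would read on this nitrogen.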